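Fluoro for methyl on the sulfonyl aryl of a cinnamoyl sulfonamide

The source may hold more compounds than are shown below. What is called first, only, known or untested is meant among the compounds shown, and "the series" means these compounds.

Two acyl sulfonamides have been measured in a functional assay on B16-F10 cells (Mus musculus) for antiproliferative activity, read by ELISA and MTT assay, with a stated time of 48 h; on this read-out lower numbers stand for stronger inhibition and higher numbers for weaker inhibition. Compound 1 `CN(C)c1ccc(/C=C/C(=O)NS(=O)(=O)c2ccc(F)cc2)cc1` gives 2.3 ug/mL. Compound 2 `Cc1ccc(S(=O)(=O)NC(=O)/C=C/c2ccc([N+](=O)[O-])cc2)cc1` gives 13.5 ug/mL, the higher of the two numbers, and the gap to compound 1 lies beyond the scatter of this assay; the two compounds differ at more than one place, so their values show only the gap itself.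

Compound 3 `O=C(/C=C/c1ccc([N+](=O)[O-])cc1)NS(=O)(=O)c1ccc(F)cc1` has not yet been measured. It differs from compound 2 by fluoro in place of methyl on an aromatic carbon. Among the measured compounds shown here, no pair among the measured compounds isolates this exchange, so the expected step from compound 2 to compound 3 rests on the size of the change alone, and a step within the scatter, with no clear direction, is expected for a 1.2-fold lower number from compound 2 to compound 3 (0.09 log units; within the scatter). In this assay compound 3 is therefore expected to give about 11 ug/mL, within a range from 5 ug/mL to 25 ug/mL.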

Compound 3, half-maximal inhibitory concentration: 2.2 ug/mL
The estimate for compound 3 lay 5.0-fold (0.70 log units) above the measured number, outside the stated range (below it).
By their numbers in this assay, from the lowest: compounds 3 and 1 (each within the scatter of the next); then compound 2.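

In this assay, the exchange of 4-methylphenyl to 4-fluorophenyl is not silent: with the nitro group held fixed, the data show a 6.1-fold lower number from compound 2 to compound 3 (0.79 log units; beyond the scatter) and so mark this aromatic carbon as a place where the read-out responds. With the 4-fluorophenyl group held fixed, the data show a 1.0-fold lower number from compound 1 to compound 3 (0.02 log units; within the scatter) for the exchange at the other end of the molecule, so nitro and dimethylamino cannot be told apart here. No measurement shown here accounts for either result.

On these data alone, the effect of fluoro in place of methyl rests on this single pair, so whether it also holds with dimethylamino in place of nitro remains open. As far as these compounds go, whether chloro or methoxy on the same carbon would fall with fluoro or with methyl is also open.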